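Bromine to hydrogen on the pendant aryl ring

A few compounds are considered here, and "the series" means these few. Any claim that something is new, unique, unknown or untested is made for them only; others in the source may bear on it.

Compound 1 `O=C(Nc1ccc(Oc2ccnc3[nH]ccc23)c(F)c1)c1nn(-c2ccc(Br)cc2)ccc1=O`: 11600 nM
Compound 2 `O=C(Nc1ccc(Oc2ccnc3[nH]ccc23)c(F)c1)c1nn(-c2ccccc2)ccc1=O`: 34900 nM
Compound 3 `Cn1ccc2c(Oc3ccc(NC(=O)c4nn(-c5ccc(Br)cc5)ccc4=O)cc3)ccnc21`: 16300 nM

In a functional assay on MCF7 cells (Homo sapiens) for cytotoxicity, read by MTT assay, with a stated time of 72 h (a lower number here means a stronger inhibitor, a higher number a weaker inhibitor), compound 1 gives 11600 nM, while compound 2 gives 34900 nM. The change between them, (hydrogen in place of bromo on an aromatic carbon), produced a 3.0-fold higher number from compound 1 to compound 2 (0.48 log units; beyond the scatter). Compound 3, on a different core, gives 16300 nM in this assay; the difference between the two cores is not broken down here. Compound 4 `Cn1ccc2c(Oc3ccc(NC(=O)c4nn(-c5ccccc5)ccc4=O)cc3)ccnc21` carries the same change as compound 2 relative to compound 1, namely (hydrogen in place of bromo on an aromatic carbon), at the same kind of place. Because compound 1 to compound 2 gave a 3.0-fold higher number from compound 1 to compound 2 (0.48 log units; beyond the scatter), a similar loss is expected from compound 3 to compound 4, that is a 2.8-fold higher number from compound 3 to compound 4 (0.44 log units; beyond the scatter). Compound 4 is thus estimated at 45000 nM in this assay, likely between 20000 nM and 110000 nM.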

Compound 4, half-maximal inhibitory concentration: 45200 nM
The estimate for compound 4 lay 1.0-fold (0.00 log units) below the measured number; low and high end bracket the measured number.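

In this assay, going from 4-bromophenyl to phenyl gave a 2.8-fold higher number from compound 3 to compound 4 (0.44 log units; beyond the scatter). The loss seen on the core of compound 1 therefore recurred on the second core at a matching size: the same change on two cores in this assay, a 3.0-fold higher number (0.48 log units; beyond the scatter) from compound 1 to compound 2 and a 2.8-fold higher number (0.44 log units; beyond the scatter) from compound 3 to compound 4, 1.1-fold (0.04 log units) apart, within the scatter of two such steps

Within the data shown here, this rests on only two matched pairs in one cell assay, so it does not show that the change would carry over to other cores or other assays, and it gives no reason for the loss.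

The compounds shown leave open whether chloro, methoxy or an amine in place of the bromo would match it. As far as these compounds go, how much the fluoro group and the methyl group that separate the two cores each contribute also stays open.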